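This account rests on a few compounds, and the source may have more. Where it says the series, first, only, none or still open, it means among the compounds named here.

The measured compounds and their values:

Compound 1, `S=C(N/N=C/c1ccc(Oc2ccc3ccccc3c2)cc1)Nc1ccc(Cl)cc1`, gives 6.96 in a physicochemical assay for lipophilicity, in phosphate buffer, measured as octanol-water partition, with a stated time of 24 h; on this read-out lower numbers stand for lower lipophilicity and higher numbers for higher lipophilicity.
Compound 2, `S=C(N/N=C/c1ccc(Oc2ccc3ccccc3c2)cc1)Nc1ccccc1`, gives 6.07 in this assay.
Compound 3, `Cc1cc(Oc2ccc(/C=N/NC(=S)Nc3ccccc3)cc2)ccc1Cl`, gives 6.03 in this assay.

Compounds 1 and 2 share the same core and differ in one place only: chloro in place of hydrogen on an aromatic carbon. This single change gives a number 0.89 log units higher from compound 2 to compound 1 (beyond the scatter). Compound 3 has a different core; how the core of compound 3 differs from the core of compound 2 is not broken down here, and their two values lie within the scatter of each other, so nothing can be read from that pair about order.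

Compound 4, `Cc1cc(Oc2ccc(/C=N/NC(=S)Nc3ccc(Cl)cc3)cc2)ccc1Cl`, has not yet been measured in this assay. It is the partner of compound 3 in the same sense that compound 1 is the partner of compound 2: chloro in place of hydrogen on an aromatic carbon. The place of the change is described in the same words for both pairs, so this is the same change, made on a different core.

Within the data shown here, the expectation for compound 4 therefore rests on the one measured example. The step is expected to be a number 0.87 log units higher from compound 3 to compound 4 (beyond the scatter) because a number 0.89 log units higher from compound 2 to compound 1 (beyond the scatter). For compound 4 the estimated value in this assay is 6.9, with a likely range from 6.5 to 7.3.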

Compound 4, partition coefficient: 6.59
Compound 4: middle estimate off by 0.31 log units, on the high side, and the stated range covers the measured number.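

In this assay, chloro in place of hydrogen on an aromatic carbon moves the number the same way on both cores, giving a number 0.89 log units higher from compound 2 to compound 1 (beyond the scatter) and then, on the second core, a number 0.56 log units higher from compound 3 to compound 4 (beyond the scatter) as a smaller step, so the direction of the change carried across, but its printed size did not repeat exactly. The two cores also stand differently with and without the chloro: 4-chloro-3-methylphenyl in place of naphthalen-2-yl gives a number 0.37 log units lower from compound 1 to compound 4 (beyond the scatter) when the chloro is present, whereas without it compound 2 gives 6.07 and compound 3 gives 6.03, two values within the scatter of each other, and two pairs are too few to fix a general size for this step or to predict it on a further core. Nothing measured here explains why the step came out smaller on the second core.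

The compounds shown hold only chloro at this place, so whether fluoro, methoxy or an amine on the same aromatic carbon would move the number in the same direction stays open. On these data alone, whether the chloro step keeps its direction on a third core, for example one with a longer chain on the oxygen, also stays open.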